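Carbamoyl for Thiocarbamoyl at the Chain Nitrogen

The compounds below may be only part of what the source reports. "The series", "measured", "known", "first", "only" and "open" are said of these compounds alone.

Compound 3 `CCNC(=S)NCCC(O)c1cc(Cl)ccc1N` gives 60.4% in an assay for inhibition of Nitric oxide synthase, inducible (Homo sapiens), read by scintillation counting, with a stated time of 30 min, tested at 1 mM (a higher number here means more inhibition at the concentration tested (going by the name of the read-out), a lower number less inhibition), the highest of the three numbers measured. Compound 2 `CNC(=S)NCCC(O)c1cc(Cl)ccc1N` gives 22.1% in this assay, and compound 1 `CCNC(=O)NCCC(O)c1ccccc1N` gives 18.3%. Within the data shown here, the only single-point step measured, a number 38.3 percentage points higher from compound 2 to compound 3 (beyond the scatter), concerns the chain on the amide-type nitrogen and not the exchange now in question. Compound 4 `CCNC(=O)NCCC(O)c1cc(Cl)ccc1N` differs from compound 3 by a group of 5 heavy atoms (3 carbon, 1 nitrogen, 1 oxygen; no ring) in place of a group of 5 heavy atoms (3 carbon, 1 nitrogen, 1 sulfur; no ring), on an amine nitrogen. Among the measured compounds shown here, no measured pair isolates this exchange; compound 1 already carries the ethylcarbamoyl group but lacks the chlorine, so its value against compound 3 shows only that the two changes together sit far lower. A drop with wide uncertainty is therefore expected: compound 4 is estimated at 35%, within 10% to 60%. This estimate corresponds to an expected a number 25.4 percentage points lower from compound 3 to compound 4 (beyond the scatter).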

Compound 4, a percentage reported as inhibition, at one concentration (the size of the read-out at that concentration, not a potency): 33.9%
Beside the measured number, compound 4's estimate is 1.1 percentage points above it; measured number inside the range.
By their numbers in this assay, from the lowest: compounds 1 and 2 (each within the scatter of the next); then compound 4; then compound 3.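

In this assay the ethylcarbamoyl group in place of the sulfur-bearing group on this amine nitrogen gives a number 26.5 percentage points lower from compound 3 to compound 4 (beyond the scatter) with the ethyl chain and chloro held constant, so the exchange of sulfur for oxygen matters here by itself. Chloro in place of hydrogen on an aromatic carbon now has its own step, a number 15.6 percentage points higher from compound 1 to compound 4 (beyond the scatter) in the carbamoyl series, whereas a number 11.8 percentage points higher from compound 2 to compound 4 (beyond the scatter) changes both chain and sulfur and assigns to neither. No evidence on the origin of these differences is available.

Still open, going by these compounds, is whether a propyl chain on this group extends the gain seen with sulfur. Bromo in place of chloro also remains open.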